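A few compounds are considered here, and "the series" means these few. Any claim that something is new, unique, unknown or untested is made for them only; others in the source may bear on it.

Compound 1 `CCCCCCCS(=O)(=O)/C=C/c1ccc(O)c(O)c1` gives 7100 nM in a functional assay, read by fluorescence and spectrophotometry, with a stated time of 1 h; a lower number here means that less compound is needed, a higher number that more compound is needed for the effect. Compound 2 `C=CCCCCCS(=O)(=O)/C=C/c1ccc(O)c(O)c1` gives 7100 nM. Compound 3 `O=S(=O)(/C=C/c1ccc(O)c(O)c1)CCCc1ccccc1` gives 11500 nM.

Compound 1 stands level with compound 2, the two together the lowest of the three numbers, with compound 3 furthest away. Compound 4 `O=S(=O)(/C=C/c1ccc(O)c(O)c1)CC1CCCC1` differs from compound 1 by cyclopentyl in place of hexyl on a saturated chain carbon bound to a sulfonyl sulfur. Two measured steps alter the same tail: no change at the digits printed from compound 1 to compound 2 (within the scatter) and a 1.6-fold higher number from compound 1 to compound 3 (0.21 log units; within the scatter), both within the scatter. Because a 1.6-fold higher number from compound 1 to compound 3 (0.21 log units; within the scatter) shows that a ring entering the tail changes little, and because no change at the digits printed from compound 1 to compound 2 (within the scatter) shows no change, the step to compound 4 is expected to be small, a 1.3-fold higher number from compound 1 to compound 4 (0.10 log units; within the scatter), if anything toward a higher number. Compound 4 is therefore estimated at 9000 nM in this assay, with a range of 4000 nM to 20000 nM.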

Compound 4, half-maximal effective concentration: 9400 nM
Compound 4: middle estimate off by 1.0-fold (0.02 log units), on the low side; the range from low to high includes it.
By their numbers in this assay, from the lowest: compounds 1, 2, 4 and 3 (each within the scatter of the next).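

In this assay, cyclopentyl on a saturated chain carbon bound to a sulfonyl sulfur shows that a non-aromatic ring of carbon only can take the place of hexyl, with a 1.3-fold higher number from compound 1 to compound 4 (0.12 log units; within the scatter) here, and of hex-5-en-1-yl, with a 1.3-fold higher number from compound 2 to compound 4 (0.12 log units; within the scatter) as well. Until now the only ring in this tail was the phenyl of compound 3, so the tolerance at this position now covers both ring types among these compounds. No measurement at hand accounts for this result. Still open, on these data alone, is whether an amine, a carboxylic acid or a longer chain in this tail would move the number beyond the scatter.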